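The source may report more compounds than this note shows. Statements on the series, on what has been measured and on what is new or still open speak of the compounds shown alone.

In a functional assay on MCF7 cells (Homo sapiens) for antiproliferative activity, read by MTT assay, with a stated time of 72 h (a higher number here means a weaker inhibitor, a lower number a stronger inhibitor), compound 1 (`CCNc1cc(C)c2cc(NC(=O)c3ccc(Cl)c(Cl)c3)ccc2n1`) gives 48600 nM and compound 2 (`CCN1CCN(c2cc(C)c3cc(NC(=O)c4ccc(Br)cc4)ccc3n2)CC1`) gives 5940 nM as the lower of the two numbers, and the gap between them lies beyond the scatter. Within the data shown here, these two compounds differ in more than one place, so their gap cannot be read as the effect of any single change, and no measured pair yet isolates a change on the carbonyl side of the amide.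

Compound 3 (`CCN1CCN(c2cc(C)c3cc(NC(=O)c4ccccc4Cl)ccc3n2)CC1`) differs from compound 2 in one place (2-chlorophenyl in place of 4-bromophenyl on a carbonyl carbon): 2-chlorophenyl in place of 4-bromophenyl on a carbonyl carbon. The rest of the structure is kept, so compound 2 at 5940 nM serves as the anchor for the expectation. Among the measured compounds shown here, with no measured step to guide it, no shift beyond the scatter is expected, only a slight lean toward a higher number, and the estimated step is a 1.3-fold higher number from compound 2 to compound 3 (0.13 log units; within the scatter) on that basis. The range is kept wide for the same lack of data. For compound 3 the expected value is 8000 nM (estimated range 2500 nM to 25000 nM).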

Compound 3, half-maximal inhibitory concentration: > 50000 nM
Compound 3: no number, only a limit (the forecaster's own chance of this, stated with the estimate: 8%); middle value at least 6.2-fold (0.79 log units) from the limit.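

Among these compounds, on the carbonyl side of the amide, the first measured step in this assay shows that this position is not indifferent to the aryl group it carries: 2-chlorophenyl in place of 4-bromophenyl on a carbonyl carbon gives an at least 8.4-fold higher number from compound 2 to compound 3 (0.92 log units; beyond the scatter). Compound 3 gives > 50000 nM, which is a limit of the assay and not a number. The step therefore fixes only a minimum size and leaves its full size unknown: the limit of > 50000 nM in this assay, at which 1 of the 3 values shown sits.

The change alters the halogen and its place on the ring together, and the compounds shown cannot separate the two; 4-chlorophenyl and 2-bromophenyl on the same carbonyl carbon would each change only one of them. Also open, from the compounds shown here alone, is whether the halogen is needed at all at this position, a question that unsubstituted phenyl, or a ring carrying an amine or a carboxylic acid, would address while the ethylpiperazine side of the series stays as in compound 2.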